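A Stereochemical Switch on a Methoxycyclohexyl Side Chain

The compounds below may be only part of what the source reports. "The series", "measured", "known", "first", "only" and "open" are said of these compounds alone.

Compound 1 `CC(C)(O)c1ccc(-c2cnc3c(n2)N(CCC2CCOCC2)C(=O)CN3)cn1` gives 88% in a functional assay on the whole organism (PC-3 cells) for inhibition, with Mus musculus as the target, in a xenograft, with a stated time of 8 h, at a dose of 100 mg/kg by the oral route; a lower number here means less inhibition, a higher number more inhibition at the dose given (going by the name of the read-out); compound 2 `CC(C)(O)c1ccc(-c2cnc3c(n2)N(CC2CCOCC2)C(=O)CN3)cn1` gives 94%; compound 3 `CO[C@H]1CC[C@@H](N2CC(=O)Nc3ncc(-c4ccc(C(C)(C)O)nc4)nc32)CC1` gives 52%.

Compound 3 stands lowest of the three measured numbers: compound 1 sits higher by a step beyond the scatter, compound 2 higher still. Compound 4 `CO[C@H]1CC[C@H](N2CC(=O)Nc3ncc(-c4ccc(C(C)(C)O)nc4)nc32)CC1` is not yet measured. It differs from compound 3 only in configuration as drawn: the two compounds have the same atoms and bonds and differ only in configuration as drawn: 2 of 2 stereo elements differ (all stereocentres are inverted: mirror images); a stereocentre at a saturated ring carbon is drawn s in compound 3 and r in compound 4; a stereocentre at a saturated ring carbon is drawn s in compound 3 and r in compound 4. Among the compounds with values here, the one measured step, a number 6 percentage points higher from compound 1 to compound 2 (within the scatter), concerns a change of chain and ring at the amide-type nitrogen, not a change of configuration, so it offers no guide to how an inverted pair of stereocentres behaves here. Within the data shown here, no measured pair shows a configuration change, so the direction and size of the step are open. Compound 4 is therefore expected to land near compound 3, with a wide margin in both directions, which means an expected step of a number 8 percentage points higher from compound 3 to compound 4 (within the scatter). The estimate for compound 4 is 60%, in a range from 25% to 92%.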

Compound 4, a percentage reported as inhibition, in the whole organism at one dose (the size of the read-out at that dose, not a potency): 85%
Compound 4: the middle estimate sits 25 percentage points below what was measured; low and high end bracket the measured number.
By their numbers in this assay, from the lowest: compound 3; then compounds 4, 1 and 2 (each within the scatter of the next).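

Compounds 1 and 2 showed only a change of chain and ring on the amide-type nitrogen, and they said nothing about how the side chain is arranged in space. In this assay, the methoxycyclohexyl side chain proves sensitive to configuration, with a number 33 percentage points higher from compound 3 to compound 4 (beyond the scatter). Since no atom or bond changes, this large step can be attributed to configuration alone, because of one fact: the fact that compounds 3 and 4 differ only in the configuration as drawn

Both stereocentres are inverted together, so the compounds shown cannot tell whether the ring carbon bound to the nitrogen, the one carrying the methoxy group, or the two together account for the step. Going by these compounds, it also remains open whether the same gap between the two configurations would hold with a hydroxyl group or a carboxylic acid in place of the methoxy group.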